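Fluoro in place of methoxy on the core of compound 2

A few compounds are considered here, and "the series" means these few. Any claim that something is new, unique, unknown or untested is made for them only; others in the source may bear on it.

Measured compounds:
compound 1, `CC(=O)c1cnc(N2CCC(c3coc4c(N5CCc6cc(S(C)(=O)=O)ccc65)ncnc34)CC2)nc1`, gives 12% in a functional assay on cells for agonist activity at Glucose-dependent insulinotropic receptor (Homo sapiens), read by a luciferase reporter, with a stated time of 4 h; on this read-out higher numbers stand for larger maximal responses and lower numbers for smaller maximal responses
compound 2, `COc1cnc(N2CCC(c3coc4c(N5CCc6cc(S(C)(=O)=O)ccc65)ncnc34)CC2)nc1`, gives 186% in this assay
compound 3, `CC(C)(C)OC(=O)N1CCC(c2coc3c(Nc4ccc(S(C)(=O)=O)cc4F)ncnc23)CC1`, gives 123% in this assay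

Compound 2 stands highest of the three numbers in this assay; compound 3 is nearest, and compound 1 furthest, both gaps beyond the scatter. Going by the values given here, the one step within the measured set, a number 174 percentage points higher from compound 1 to compound 2 (beyond the scatter), sits at the very position now varied.

Compound 4, `CS(=O)(=O)c1ccc2c(c1)CCN2c1ncnc2c(C3CCN(c4ncc(F)cn4)CC3)coc12`, differs from compound 2 by fluoro in place of methoxy on an aromatic carbon. Among the compounds with values here, the only step bearing on this change is the large one from compound 1 to compound 2, which shows that the group on this aromatic carbon moves the maximal response strongly. Within the data shown here, no measured step puts fluoro at this place; compound 3 carries a fluoro elsewhere and its value gives no direct guide. The expectation therefore is a step in this assay from compound 2 to compound 4 of moderate size downward, with a wide range, expected as a number 46 percentage points lower from compound 2 to compound 4 (beyond the scatter). For compound 4 the estimated value in this assay is 140%, expected to lie between 60% and 200%.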

Compound 4, largest response reached (Emax), in percent of the reference or control that the assay uses: 229%
Compound 4: middle estimate off by 89 percentage points, on the low side, outside the stated range (above it).
By their numbers in this assay, from the lowest: compound 1; then compound 3; then compound 2; then compound 4.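

In this assay, the change from 5-methoxypyrimidin-2-yl to 5-fluoropyrimidin-2-yl is a number 43 percentage points higher from compound 2 to compound 4 (beyond the scatter), so the methoxy group is not required for a high maximal response on this scaffold, and the single fluorine atom goes further than the methoxy group. Set against the acetyl group, the fluoro group gives a number 217 percentage points higher from compound 1 to compound 4 (beyond the scatter), and the three compounds that differ only at this aromatic carbon now rank acetyl, then methoxy, then fluoro, each step beyond the usual scatter. Nothing available here accounts for the higher response of the fluoro compound.

As far as these compounds go, three groups at one carbon on one shared core do not define a trend, so it remains open where chloro, nitrile, a dimethylamino group or plain hydrogen would fall in this order. Maximal response alone also leaves open whether compound 4 differs from compound 2 in potency, and whether the ranking of fluoro over methoxy would hold in a different assay format.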